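Methylsulfanyl for hydroxy on the fused triazine core

The compounds below may be only part of what the source reports. "The series", "measured", "known", "first", "only" and "open" are said of these compounds alone.

Of the compounds shown here, three have values so far. Compound 1 `C=CCSc1nncc2cnc(CCC)n12` is measured in a functional assay for inhibition, with Homo sapiens as the target; on this read-out higher numbers stand for weaker inhibition and lower numbers for stronger inhibition; in this assay compound 1 reaches only a limit of the assay, > 48000 nM. Compound 2 `CCCc1ncc2c(C)nnc(O)n12` likewise gives only a limit, > 48000 nM. Compound 3 `CCCc1nc(C)c2c(C)nnc(O)n12` gives a number, 14000 nM. Going by the values given here, the single step between measured neighbours, methyl in place of hydrogen on an aromatic carbon, is an at least 3.4-fold lower number from compound 2 to compound 3 (0.53 log units; beyond the scatter). Compound 2 therefore stands at the limit of > 48000 nM in this assay, at which 2 of the 3 values shown sit, with no number of its own.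

The unmeasured compound 4 `CCCc1ncc2c(C)nnc(SC)n12` differs from compound 2 by methylsulfanyl in place of hydroxy on an aromatic carbon. Among the compounds with values here, no measured step bears on this exchange: the step from compound 2 to compound 3 concerns a methyl on a different carbon, and compound 1, which also carries a sulfur substituent on its core, sits at the limit rather than at a number. The hydroxy of compound 2 is thus the only direct reference, and it is a limit. Compound 4 is expected to remain weak, with the step that the limit leaves unreadable from compound 2 to compound 4 estimated as no clear change beyond the scatter. Compound 4 is estimated at 60000 nM, within 15000 nM to 250000 nM, in this assay.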

Compound 4, half-maximal inhibitory concentration: > 48000 nM
Compound 4: a limit, no number (the forecaster's own chance of this, stated with the estimate: 65%); the middle value lies beyond the limit too.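

In this assay compound 4 gives > 48000 nM, a limit and not a number. Going by these compounds alone, compound 2 also stands at a limit, and no step from it to compound 4 can be read. The compounds shown leave open whether methylsulfanyl in place of hydroxy changes the read-out on a compound that gives a number, such as compound 3.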